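The source may hold more compounds than are shown below. What is called first, only, known or untested is meant among the compounds shown, and "the series" means these compounds.

The measured compounds, each in a functional assay on PC-3 cells (Homo sapiens) for antiproliferative activity, read by MTT assay, with a stated time of 48 h; a higher number here means a weaker inhibitor, a lower number a stronger inhibitor:
Compound 1, `COc1ccc(/C=C/C(=O)Nc2cc3ncnc(Nc4ccc(F)c(Cl)c4)c3s2)cc1`, gives 100 nM.
Compound 2, `O=C(/C=C/c1ccc(O)cc1)Nc1cc2c(Nc3ccc(Cl)c(Cl)c3)ncnc2s1`, gives 300 nM.
Compound 3, `O=C(/C=C/c1ccccc1)Nc1cc2c(Nc3ccc(F)c(Cl)c3)ncnc2s1`, gives 700 nM.

Compound 3 stands at the highest number of the three, which makes it the weakest inhibitor of this small set. Its nearest neighbour is compound 2, and the gap to it lies beyond the usual scatter; compound 1 is furthest away, and that gap is also beyond the scatter. For the measured compounds named here, no pair of measured compounds differs in one place only, so these gaps can only be read as differences between values, not as steps tied to a single change.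

Compound 4, `O=C(/C=C/c1ccccc1)Nc1cc2c(Nc3cc(Cl)cc(Cl)c3)ncnc2s1`, has not yet been measured. It differs from compound 3 in one place: 3,5-dichlorophenyl in place of 3-chloro-4-fluorophenyl on a nitrogen on an aromatic ring. Going by the values given here, no measured pair isolates this change; compounds 1 and 2 carry other halogen patterns on the same aniline, but each also differs elsewhere, so no size can be derived for it. In this assay, among the compounds with values here, a small step is expected, within the scatter or a slight weakening, since the one measured compound with two chlorines on that aniline, compound 2, does not stand out from compound 3. Compound 4 is therefore estimated at 900 nM, within 350 nM to 2500 nM, which means an expected step of a 1.3-fold higher number from compound 3 to compound 4 (0.11 log units; within the scatter).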

Compound 4, half-maximal inhibitory concentration: 390 nM
Compound 4: middle estimate off by 2.3-fold (0.36 log units), on the high side; the range from low to high includes it.
By their numbers in this assay, from the lowest: compound 1; then compounds 2, 4 and 3 (each within the scatter of the next, the first and the last beyond it).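

For the compounds shown here, compound 3 and compound 4 form the first pair that differs in one place only, so this position now has a step of its own: in this assay, 3,5-dichlorophenyl in place of 3-chloro-4-fluorophenyl on a nitrogen on an aromatic ring gives a 1.8-fold lower number from compound 3 to compound 4 (0.25 log units; within the scatter). The two values therefore cannot be told apart, and on this shared core, the exchange of the fluorine for a second chlorine, with the chlorines arranged differently on the ring, leaves no readable mark on antiproliferative activity. Nothing available bears on why this exchange behaves as it does.

From the compounds shown here alone, compound 1 and compound 2 each differ from compound 3 and compound 4 in more than one place, so the steps involving them cannot be read, and it stays open whether the same exchange would give the same result alongside the methoxy group of compound 1 or the hydroxyl group of compound 2. Also open, going by these compounds, is how the position would respond to a group carrying no halogen at all, such as a 3-ethynylphenyl or a benzyl group on that nitrogen.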